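This account rests on a few compounds, and the source may have more. Where it says the series, first, only, none or still open, it means among the compounds named here.

In an ADME assay on Vero cells (Chlorocebus sabaeus) for cytotoxicity, with a stated time of 4 days (on this read-out higher numbers stand for weaker inhibition and lower numbers for stronger inhibition), compound 1 `COc1cc2c(cc1OC)CN(S(=O)(=O)c1ccc(-n3cc(COc4ccc(C=O)cc4)nn3)cc1)CC2` gives only a limit, > 50 ug/mL. Compound 2 `COc1cc2c(cc1OC)CN(S(=O)(=O)c1ccc(-n3cc(COc4ccccc4)nn3)cc1)CC2` likewise gives only a limit in this assay, > 50 ug/mL. The step from compound 1 to compound 2 in this assay, a step that the two limits leave unreadable from compound 1 to compound 2, cannot be read because both values sit at the limit of > 50 ug/mL in this assay, at which 2 of the 2 values shown sit. Among the compounds with values here, compound 2 therefore stands at the limit of this assay, with no number of its own, and its only measured neighbour stands at the same limit.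

Compound 3 `COc1cc2c(cc1OC)CN(S(=O)(=O)c1ccc(-n3cc(COc4cc(C=O)ccc4OC)nn3)cc1)CC2` differs from compound 2 by 5-formyl-2-methoxyphenyl in place of phenyl on an oxygen on a saturated carbon. Within the data shown here, the one measured step that bears on this change is the step from compound 1 to compound 2, the removal of a formyl from an aromatic carbon, and its size is not readable. Among the measured compounds shown here, the entering group brings the formyl back together with a methoxy, and no measured step reports the effect of the methoxy. With compound 1 and compound 2 both at the limit, no step beyond the scatter is expected in this assay; the expected step is a step that the limit leaves unreadable from compound 2 to compound 3. Compound 3 is thus expected to come out at about 60 ug/mL, within a range from 30 ug/mL to 120 ug/mL, most likely again as a limit.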

Compound 3, half-maximal inhibitory concentration: > 50 ug/mL
Compound 3 gave a limit, no number; the forecaster's own chance of this, stated with the estimate: 80%; the middle value lies beyond the limit too.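

In this assay compound 3 gives > 50 ug/mL as a limit and not a number. Within the data shown here, no step from compound 1 or compound 2 to compound 3 can be read, as all three compounds sit together: the limit of > 50 ug/mL in this assay, at which 3 of the 3 values shown sit.

The compounds shown leave open whether the formyl or the methoxy has any effect on cytotoxicity, and how far each compound lies beyond the limit.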